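Compound 1 to compound 4: adding a carbonyl

The compounds below may be only part of what the source reports. "The series", "measured", "known", "first", "only" and "open" are said of these compounds alone.

In a functional assay on OVCAR-3 cells (Homo sapiens) for antiproliferative activity, read by MTT assay, with a stated time of 24 h (a lower number here means a stronger inhibitor, a higher number a weaker inhibitor), compound 1 `Cc1ccccc1NNC(=O)c1cccc(NS(=O)(=O)c2cnc(O)nc2O)c1` gives > 20000 nM, a limit of the assay and not a number. Of the two other measured compounds, compound 2 `O=C(NNc1ccccc1Cl)c1ccccc1NS(=O)(=O)c1cnc(O)nc1O` gives 14100 nM and compound 3 `O=C(NNC(=O)c1ccccc1Cl)c1ccc(NS(=O)(=O)c2cnc(O)nc2O)cc1` gives 5220 nM. Among the measured compounds shown here, no step between measured compounds that differ in one place is available, so the series offers no direct measure of a single change.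

Compound 4 `Cc1ccccc1C(=O)NNC(=O)c1cccc(NS(=O)(=O)c2cnc(O)nc2O)c1` differs from compound 1 by (2-methylphenyl)carbonyl in place of 2-methylphenyl on an amine nitrogen. For the measured compounds named here, compound 3, at 5220 nM, is the only measured compound that also has a carbonyl on that nitrogen, and this single case is the whole basis for expecting a moderate gain in this assay. The expected step of an at least 2.2-fold lower number from compound 1 to compound 4 (0.34 log units; beyond the scatter) is towards stronger inhibition, and its size remains loose. A reading at the limit would not be a surprise. For compound 4 the estimated value is 9000 nM, with an expected range of 3500 nM to 20000 nM.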

Compound 4, half-maximal inhibitory concentration: > 20000 nM
Compound 4 gave a limit, no number; the forecaster's own chance of this, stated with the estimate: 25%; at least 2.2-fold (0.34 log units) between middle value and limit.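

In this assay compound 4 gives > 20000 nM, a limit of the assay and not a number, and with compound 1 also at a limit no step between the two can be read: the limit of > 20000 nM in this assay, at which 2 of the 4 values shown sit.

The compounds shown leave open whether adding the carbonyl on that amine nitrogen changes activity at all.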